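The source may report more compounds than this note shows. Statements on the series, on what has been measured and on what is new or still open speak of the compounds shown alone.

Values in a functional assay on MDA-MB-436 cells (Homo sapiens) for antiproliferative activity, read by MTT assay, with a stated time of 48 h; on this read-out higher numbers stand for weaker inhibition and lower numbers for stronger inhibition
- compound 1 (`C=CS(=O)(=O)N1CCN(c2ncnc3sc(-c4ccc(C#N)cc4)cc23)CC1`) (9170 nM)
- compound 2 (`CCCNC(=O)N1CCN(c2ncnc3sc(-c4ccc(N5CCN(C)CC5)cc4)cc23)CC1`) (12400 nM)

Compound 2 (12400 nM) and compound 1 (9170 nM) lie within the scatter of each other, so neither stands apart on these numbers. Compound 3 (`CN1CCN(c2ccc(-c3cc4c(N5CCN(C(=O)Nc6ccc(Cl)cc6)CC5)ncnc4s3)cc2)CC1`) differs from compound 2 by 4-chlorophenyl in place of propyl on an amide-type nitrogen. Within the data shown here, no measured pair shows a change at this place, so the expectation is loose: a moderate step toward a lower number in this assay. The expected step is (a 2.5-fold lower number from compound 2 to compound 3 (0.39 log units; beyond the scatter)). Compound 3 is estimated at (5000 nM), with an expected range (1500 nM to 15000 nM).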

Compound 3, half-maximal inhibitory concentration: 9270 nM
Beside the measured number, compound 3's estimate is 1.9-fold (0.27 log units) below it; low and high end bracket the measured number.
By their numbers in this assay, from the lowest: compounds 1, 3 and 2 (each within the scatter of the next).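

On the amide-type nitrogen, replacing propyl with 4-chlorophenyl gives a 1.3-fold lower number from compound 2 to compound 3 (0.13 log units; within the scatter) in this assay. Among these compounds, this is the first matched pair at this place, and it shows that a six-membered aromatic ring and a propyl chain cannot be told apart here on these numbers. No available evidence bears on this result.

Still open, as far as these compounds go, is whether a longer chain, a carboxylic acid or an amine in place of 4-chlorophenyl on this nitrogen would move the number beyond the scatter.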